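Replacing the furan of compound 3 with a carboxymethyl-bearing phenyl

A few compounds are considered here, and "the series" means these few. Any claim that something is new, unique, unknown or untested is made for them only; others in the source may bear on it.

The series shares one amide core, shown in compound 1 `CC(C)N(Cc1cccc(OCCCCCC(=O)O)c1)C(=O)c1ccc(-c2ccncc2)cc1`, compound 2 `CC(C)N(Cc1cccc(OCCCCCC(=O)O)c1)C(=O)c1ccc(-c2ccco2)cc1` and compound 3 `CCOC(=O)CCCCCOc1cccc(CN(C(=O)c2ccc(-c3ccco3)cc2)C(C)C)c1`. In an ADME assay on HEK293 cells (Homo sapiens) for cytotoxicity, read by CellTiter-Glo and resazurin assay, with a stated time of 72 h (a lower number here means that less compound is needed, a higher number that more compound is needed for the effect), compound 1 gives only a limit, > 26000 nM. In this assay compound 2 likewise reaches only the limit, > 26000 nM. In this assay compound 3 again stops at the limit, > 26000 nM. Compound 3 therefore stands where all three measured compounds stand, as the limit of > 26000 nM in this assay, at which 3 of the 3 values shown sit, records. Among the measured compounds shown here, the two measured steps, a step that the two limits leave unreadable from compound 1 to compound 2 and a step that the two limits leave unreadable from compound 2 to compound 3, carry no readable size, so no step in this assay can be quantified from them. Compound 4 `CCOC(=O)CCCCCOc1cccc(CN(C(=O)c2ccc(-c3cccc(CC(=O)O)c3)cc2)C(C)C)c1` differs from compound 3 in one place: 3-(carboxymethyl)phenyl in place of furan-2-yl on an aromatic carbon. For the measured compounds named here, no measured step speaks to this change, and the three limits only show that nothing has yet produced a readable number. Compound 4 is therefore expected to sit at the limit as well, with a step that the limit leaves unreadable from compound 3 to compound 4 not distinguishable from none. The estimate for compound 4 is 40000 nM, ranging from 20000 nM to 120000 nM.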

Compound 4, half-maximal effective concentration: > 26000 nM
Compound 4 was reported as a limit; the forecaster's own chance of this, stated with the estimate: 85%; the middle value is on the limit's open side.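

In this assay compound 4, like compound 3, gives only a limit, so the change from compound 3 to compound 4 yields no readable step. The compounds shown leave open where, if anywhere, any of them would give a readable number, as all share one limit: the limit of > 26000 nM in this assay, at which 4 of the 4 values shown sit.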